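This account rests on a few compounds, and the source may have more. Where it says the series, first, only, none or still open, it means among the compounds named here.

Measured so far:
compound 1, `O=C1/C(=C/c2ccccc2F)CCc2ccc(O)cc21`, 1350 nM
compound 2, `O=C1/C(=C/c2ccc(F)cc2)CCc2ccc(O)cc21`, 840 nM
compound 3, `O=C1/C(=C/c2ccccc2C(F)(F)F)CCc2ccc(O)cc21`, 1020 nM

All three numbers come from a functional assay on RAW264.7 cells (Mus musculus) for inhibition; on this read-out higher numbers stand for weaker inhibition and lower numbers for stronger inhibition. Compound 1 and compound 2 are built from the same atoms joined differently; the difference between the two cores is not broken down here. The three values sit close together, and none of the gaps between them reaches beyond the usual scatter, so no ordering among them can be claimed. Compound 3 arises from compound 1 by trifluoromethyl in place of fluoro on an aromatic carbon, and that change gave a 1.3-fold lower number from compound 1 to compound 3 (0.12 log units; within the scatter). The unmeasured compound 4, `O=C1/C(=C/c2ccc(C(F)(F)F)cc2)CCc2ccc(O)cc21`, arises from compound 2 by trifluoromethyl in place of fluoro on an aromatic carbon. This is the same kind of change, but the place differs: in compound 3 the new group sits ortho to a large group, in compound 4 para to a large group. Resting on a 1.3-fold lower number from compound 1 to compound 3 (0.12 log units; within the scatter), a step of about a 1.1-fold lower number from compound 2 to compound 4 (0.05 log units; within the scatter) is expected here as well. Compound 4 is therefore estimated at 750 nM in this assay, most likely between 350 nM and 1600 nM.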

Compound 4, half-maximal inhibitory concentration: > 10000 nM
Compound 4: only a limit was reported; the forecaster's own chance of this, stated with the estimate: 3%; middle value at least 13-fold (1.12 log units) away from the limit.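

In this assay compound 4 gives > 10000 nM, which is a limit of the assay and not an exact number. Trifluoromethyl in place of fluoro gave an at least 11-fold higher number from compound 2 to compound 4 (1.07 log units; beyond the scatter), so the effect of this change did not carry over from one core to the other: the same change on two cores in this assay, a 1.3-fold lower number (0.12 log units; within the scatter) from compound 1 to compound 3 and an at least 11-fold higher number (1.07 log units; beyond the scatter) from compound 2 to compound 4, at least 15-fold (1.19 log units) apart, beyond the scatter of two such steps With only one pair for each core, and the new group placed differently in each pair, this does not show why the two steps part or how the change would behave on other cores.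

The compounds shown leave open whether the loss of inhibition is tied to trifluoromethyl itself. A nitrile, a methoxy group or a carboxylic acid para to a large group could help settle this.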